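The source may hold more compounds than are shown below. What is called first, only, known or untested is meant among the compounds shown, and "the series" means these compounds.

Measured compounds:
- compound 1, `Cn1c(Cc2nn(C)c(=O)c3ccccc23)nnc1SCCCCCCCC(=O)Nc1ccc(O)cc1O`: 17000 nM
- compound 2, `COc1ccc(NC(=O)CCCCCCCSc2nnc(Cc3nn(C)c(=O)c4ccccc34)n2C)cc1`: 3900 nM

Among the compounds with values here, in an assay on isolated protein (Mus musculus) for inhibition of IL15-IL15 receptor (Homo sapiens), read by resazurin assay, with stated times of 30 min and 2.5 days (a lower number here means a stronger inhibitor, a higher number a weaker inhibitor), compound 2 gives the lowest of the two numbers, with compound 1 as its only neighbour, a higher number. Within the data shown here, the only step so far, a 4.4-fold lower number from compound 1 to compound 2 (0.64 log units; beyond the scatter), shows a 4-methoxyphenyl on the amide-type nitrogen giving a lower number than a 2,4-dihydroxyphenyl. Compound 3, `Cn1c(Cc2nn(C)c(=O)c3ccccc23)nnc1SCCCCCCCC(=O)Nc1ccccc1O`, follows the change (2-hydroxyphenyl in place of 4-methoxyphenyl on an amide-type nitrogen); it keeps one hydroxyl of compound 1 and drops the methoxy of compound 2, so it sits between the two measured compounds in structure. Among the measured compounds shown here, the single step bearing on it was modest and ran against the hydroxyl-bearing ring, so compound 3 is expected to land between its two neighbours, a somewhat higher number than compound 2, meaning a 1.8-fold higher number from compound 2 to compound 3 (0.25 log units; within the scatter). The estimate for compound 3 in this assay is 7000 nM, with a range from 2500 nM to 20000 nM.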

Compound 3, half-maximal inhibitory concentration: 27000 nM
Compound 3: the middle estimate sits 3.9-fold (0.59 log units) below what was measured, outside the stated range (above it).
By their numbers in this assay, from the lowest: compound 2; then compounds 1 and 3 (each within the scatter of the next).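

In this assay the new step on the amide-type nitrogen, a 6.9-fold higher number from compound 2 to compound 3 (0.84 log units; beyond the scatter), is larger than the first step and goes the same way: both hydroxyl-bearing rings give higher numbers than the 4-methoxyphenyl of compound 2. Removing one hydroxy from the 2,4-dihydroxyphenyl ring gives a 1.6-fold higher number from compound 1 to compound 3 (0.20 log units; within the scatter), so compound 1 and compound 3 cannot be told apart in this assay, and that hydroxy has no readable effect here. Nothing in the data given explains the gap between the methoxy-bearing ring and the hydroxyl-bearing rings.

The step from compound 2 to compound 3 changes both the group and its place on the ring, so the two changes cannot be separated. As far as these compounds go, a 2-methoxyphenyl, a 4-hydroxyphenyl or a plain phenyl on the same nitrogen would be needed to tell them apart, and how those groups would read remains open.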